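From Ethyl to tert-Butyl on the Shared Core

This account rests on a few compounds, and the source may have more. Where it says the series, first, only, none or still open, it means among the compounds named here.

In a functional assay on A549 cells (Homo sapiens) for antiproliferative activity, read by MTT assay, with a stated time of 18 h (a higher number here means a weaker inhibitor, a lower number a stronger inhibitor), compound 1 `Cc1cc2c(OCc3cc(-c4ccc(Cl)cc4)no3)ncnc2s1` gives 2790 nM and compound 2 `CCc1cc2c(OCc3cc(-c4ccc(Cl)cc4)no3)ncnc2s1` gives 45500 nM, the higher of the two numbers. Compound 3 `CC(C)(C)c1cc2c(OCc3cc(-c4ccc(Cl)cc4)no3)ncnc2s1` differs from compound 2 by tert-butyl in place of ethyl on an aromatic carbon. Within the data shown here, only one measured step bears on this change, and it is large: a 16-fold higher number from compound 1 to compound 2 (1.21 log units; beyond the scatter). That single step is thin support, so only a small further rise, not clearly beyond the scatter, is expected. The expected change is a 1.5-fold higher number from compound 2 to compound 3 (0.19 log units; within the scatter). Compound 3 is estimated at 70000 nM, with an expected range from 15000 nM to 250000 nM.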

Compound 3, half-maximal inhibitory concentration: 159000 nM
Compound 3: middle estimate off by 2.3-fold (0.36 log units), on the low side; the range from low to high includes it.
By their numbers in this assay, from the lowest: compound 1; then compound 2; then compound 3.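

In this assay, tert-butyl in place of ethyl on this aromatic carbon next to the ring sulfur gives a 3.5-fold higher number from compound 2 to compound 3 (0.54 log units; beyond the scatter), so the rise seen with ethyl continues, though as a modest step. Measured from methyl, the change gives a 57-fold higher number from compound 1 to compound 3 (1.76 log units; beyond the scatter), and the number rises in the order methyl, ethyl, tert-butyl across these three compounds, with none going against that order. As far as these compounds go, whether an amine, a carboxylic acid or plain hydrogen at this place would give a lower number than compound 1 stays open. Nothing available here gives a reason for this rise.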